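Swapping the Sulfonyl Phenyl for a Bridged Bicyclic Amine

The source may report more compounds than this note shows. Statements on the series, on what has been measured and on what is new or still open speak of the compounds shown alone.

Three measured compounds share one core and differ only in the group on the sulfonyl sulfur. In an ADME assay (liver) for metabolic stability, with Liver microsome (Homo sapiens) as the target, using microsomes, with a stated time of 30 min, tested at 1 uM (a higher number here means that more of the compound is left, a lower number that less of the compound is left), compound 1 `COc1cccc(S(=O)(=O)c2ccc(CN/C(=N\C#N)Nc3ccncc3)cc2)c1` gives 55%, compound 2 `N#C/N=C(\NCc1ccc(S(=O)(=O)c2cccc(C(F)(F)F)c2)cc1)Nc1ccncc1` gives 62%, and compound 3 `N#C/N=C(\NCc1ccc(S(=O)(=O)c2ccccc2)cc1)Nc1ccncc1` gives 96%, the highest of the three. The step of a number 41 percentage points higher from compound 1 to compound 3 (beyond the scatter) and the step of a number 34 percentage points higher from compound 2 to compound 3 (beyond the scatter) were both large, while the step of a number 7 percentage points higher from compound 1 to compound 2 (within the scatter) stayed within the scatter. Compound 4 `N#C/N=C(\NCc1ccc(S(=O)(=O)N2CC3CCC(C2)O3)cc1)Nc1ccncc1` carries a group of 8 heavy atoms (6 carbon, 1 nitrogen, 1 oxygen; one five-membered non-aromatic ring with 1 hetero atom, one six-membered non-aromatic ring with 2 hetero atoms) in place of a group of 6 heavy atoms (6 carbon; one six-membered aromatic ring of carbon only), on a sulfonyl sulfur. Among the measured compounds shown here, none of the measured steps touches this part of the molecule: all three kept the phenyl and varied only what sits on it, so they give no direct guide. Compound 3 already stands at 96%, near the top of the scale, so the expected step of a number 14 percentage points lower from compound 3 to compound 4 (beyond the scatter) is downward or none beyond the scatter. Compound 4 is therefore estimated at 82%, with a range from 55% to 98%.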

Compound 4, percent of the compound remaining: 60%
The estimate for compound 4 lay 22 percentage points above the measured number; measured number inside the range.
By their numbers in this assay, from the lowest: compounds 1, 4 and 2 (each within the scatter of the next); then compound 3.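

Putting the bridged bicyclic amine on the sulfonyl sulfur in place of phenyl gives a number 36 percentage points lower from compound 3 to compound 4 (beyond the scatter) in this assay and so shows that the group on the sulfur itself matters, not only what sits on the phenyl. The amine sits level with the substituted phenyls, with a number 2 percentage points lower from compound 2 to compound 4 (within the scatter) and a number 5 percentage points higher from compound 1 to compound 4 (within the scatter) so that only compound 3 stands apart. Nothing at hand explains the drop from the plain phenyl.

From the compounds shown here alone, whether a simpler amine on the sulfonyl sulfur, such as piperidine or morpholine, would come closer to compound 3 stays open.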